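Hydroxy to Carboxy Swap: Expected Effect on Cell Growth

The source may report more compounds than this note shows. Statements on the series, on what has been measured and on what is new or still open speak of the compounds shown alone.

Measured so far:
- compound 1 `Cc1c(C(=O)Nc2c(F)cc(-c3cccc(F)c3)cc2F)nc2ccc(F)cc2c1O`: 0%
- compound 2 `COc1ccc2nc(C(=O)Nc3ccc(-c4ccccc4)cc3)c(C)c(O)c2c1`: 3.05%
- compound 3 `Cc1c(C(=O)Nc2c(F)cc(-c3cccc(F)c3)cc2F)nc2ccc(F)cc2c1C(=O)O`: 1.05%

All three were tested in a functional assay on A-375 cells (Homo sapiens) for antiproliferative activity, read by MTT assay, with a stated time of 24 h, tested at 0.14 ug/mL; a lower number here means a weaker effect, a higher number a stronger effect of the compound at the concentration tested. Compound 1 and compound 3 differ in one place: carboxy in place of hydroxy on an aromatic carbon. In this assay this gave a step of a number 1.1 percentage points higher from compound 1 to compound 3 (within the scatter). Compound 2 is built on a different core; the difference between the two cores is not broken down here. Compound 4 `COc1ccc2nc(C(=O)Nc3ccc(-c4ccccc4)cc3)c(C)c(C(=O)O)c2c1` has not yet been measured. It differs from compound 2 by the same change: carboxy in place of hydroxy on an aromatic carbon. For the measured compounds named here, the earlier step of a number 1.1 percentage points higher from compound 1 to compound 3 (within the scatter) is the only guide available. On that basis, a step of a number 1 percentage points higher from compound 2 to compound 4 (within the scatter) is expected in this assay. Compound 4 is therefore estimated at 4%, with a range from -5% to 13%.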

Compound 4, a percentage reported as inhibition, at one concentration (the size of the read-out at that concentration, not a potency): 3.65%
Estimate against measurement, compound 4: 0.4 percentage points above, and the stated range covers the measured number.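

On the core of compound 2, replacing hydroxy with carboxy gave a step of a number 0.6 percentage points higher from compound 2 to compound 4 (within the scatter) in this assay. Set beside the earlier step, the change looks alike on the two cores: the same change on two cores in this assay, a number 1.1 percentage points higher (within the scatter) from compound 1 to compound 3 and a number 0.6 percentage points higher (within the scatter) from compound 2 to compound 4, 0.5 percentage points apart, within the scatter of two such steps. For the compounds shown here, both steps lie within the scatter, so this shows only that the swap leaves no readable mark on either core at this one concentration; it does not show that the change would carry over in the same way to a compound with a clear effect.

The compounds shown leave open what an amine or a longer chain would do in place of the hydroxy. They also leave open how either core would respond to the swap at other concentrations.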